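This account rests on a few compounds, and the source may have more. Where it says the series, first, only, none or still open, it means among the compounds named here.

Measured values in an ADME assay on RAW264.7 cells (Mus musculus) for cytotoxicity, read by luminescence and CellTiter-Glo, with a stated time of 18 h, tested at 1 uM; on this read-out lower numbers stand for a stronger effect and higher numbers for a weaker effect at the one concentration tested:
compound 1, `C=C1CC[C@H]2C(C)(C)CCC[C@]2(C)[C@H]1C[C@@H](O)C1=CCOC1=O`, 111%
compound 2, `C=C1CC[C@H]2C(C)(C)CCC[C@]2(C)[C@H]1C/C=C1\CC(O)OC1=O`, 92.7%
compound 3, `C=C1CC[C@H]2C(C)(C)CCC[C@]2(C)[C@H]1C/C=C1\C=COC1=O`, 97.7%

Among these three, compound 3 holds the second highest number. Its nearest neighbour is compound 2, whose value lies lower by an amount within the scatter, so the two cannot be told apart. Compound 1 is furthest from it, higher by an amount beyond the scatter. Compound 4, `C=C1CC[C@H]2C(C)(C)CCC[C@]2(C)[C@H]1CC=O`, has not yet been measured in this assay. Among the compounds with values here, it differs from compound 3 in one place: a group of 2 heavy atoms (1 carbon, 1 oxygen; no ring) in place of a group of 7 heavy atoms (5 carbon, 2 oxygen; one five-membered non-aromatic ring with 1 hetero atom), on a saturated chain carbon bound to a saturated ring carbon No step between measured compounds is available, and the three measured values lie close together, so the step in this assay is expected to be small, in no particular direction and not beyond the scatter. Compound 4 is therefore expected to give 98%, between 84% and 112%. The step of a number 0.3 percentage points higher from compound 3 to compound 4 (within the scatter) is expected to stay within the scatter.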

Compound 4, a percentage reported as activity, at one concentration (the size of the read-out at that concentration, not a potency): 101%
Compound 4: middle estimate off by 3 percentage points, on the low side, and the stated range covers the measured number.
By their numbers in this assay, from the lowest: compounds 2, 3, 4 and 1 (each within the scatter of the next, the first and the last beyond it).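

In this assay, exchanging the group of 7 heavy atoms with its five-membered non-aromatic ring for formyl, on a saturated chain carbon bound to a saturated ring carbon, gives a number 3.3 percentage points higher from compound 3 to compound 4 (within the scatter). At this position, therefore, the ring-bearing group can give way to a much smaller group without a shift beyond the scatter. Nothing available explains this outcome.

The compounds shown leave open whether an amine or a carboxylic acid at this place would also stay within the scatter. They likewise leave open what a longer chain would do here.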